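The source may hold more compounds than are shown below. What is called first, only, known or untested is meant among the compounds shown, and "the series" means these compounds.

Compound 1 `CC1=NC(C)=C(C(=O)O)C(c2cccc(C)c2)/C1=C(\O)OC/C=C/c1ccccc1` gives 76 nM in a functional assay on thoracic aorta for inhibition of Voltage-gated L-type calcium channel (Rattus norvegicus); on this read-out higher numbers stand for weaker inhibition and lower numbers for stronger inhibition.
Compound 2 `CC1=NC(C)=C(C(=O)O)C(c2cccc(Cl)c2)/C1=C(\O)OC/C=C/c1ccccc1` gives 20 nM in this assay.
Compound 3 `CC1=NC(C)=C(C(=O)O)C(c2ccoc2)/C1=C(\O)OC/C=C/c1ccccc1` gives 130 nM in this assay.

The three measured compounds share one core and differ only in the aromatic group on the saturated ring carbon. Compound 2 stands at the lowest of the three numbers in this assay: the step of a 3.8-fold lower number from compound 1 to compound 2 (0.58 log units; beyond the scatter) separates it from compound 1, and the step of a 6.5-fold higher number from compound 2 to compound 3 (0.81 log units; beyond the scatter) separates it from compound 3, so both neighbours lie beyond the scatter above it. The step of a 1.7-fold higher number from compound 1 to compound 3 (0.23 log units; within the scatter) shows that compound 1 and compound 3 cannot be told apart.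

Compound 4 `CC1=NC(C)=C(C(=O)O)C(c2cccc(Cl)c2)/C1=C(\O)OCc1ccc2ccccc2c1` keeps the 3-chlorophenyl group of compound 2 and changes a different part of the molecule: naphthalen-2-yl in place of 2-phenylethenyl on a saturated chain carbon bound to an oxygen on an unsaturated carbon. Going by the values given here, none of the measured steps touches this part; every one of them concerns the aromatic group on the saturated ring carbon, while the 2-phenylethenyl group is the same in compound 1, compound 2 and compound 3. The data therefore give no direct guide for this change. Since both the group that leaves and the group that enters are hydrocarbon aromatic groups of similar size, the expected step for compound 4 in this assay is a 1.3-fold higher number from compound 2 to compound 4 (0.10 log units; within the scatter), that is, none beyond the scatter. Compound 4 is estimated at 25 nM, with a range from 8 nM to 80 nM.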

Compound 4, half-maximal inhibitory concentration: 14 nM
For compound 4 the middle estimate is 1.8-fold (0.25 log units) above the measured one; the measured number falls inside the stated range.
By their numbers in this assay, from the lowest: compounds 4 and 2 (each within the scatter of the next); then compounds 1 and 3 (each within the scatter of the next).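

Going by these compounds alone, the place on a saturated chain carbon bound to an oxygen on an unsaturated carbon can now be read for the first time, since all the earlier steps concerned the aromatic group on the saturated ring carbon. In this assay, replacing 2-phenylethenyl with naphthalen-2-yl gives a 1.4-fold lower number from compound 2 to compound 4 (0.15 log units; within the scatter) while the 3-chlorophenyl group stays fixed, so this pair shows that a group with two six-membered aromatic rings of carbon only can stand here in place of one with a single such ring and a double bond outside it, with no difference that can be told from the scatter. No measurement on hand says why these two groups read alike.

From the compounds shown here alone, this rests on a single pair, so it remains open whether the same exchange would read alike with 3-methylphenyl or furan-3-yl on the saturated ring carbon. The compounds shown also leave open how this place would respond to a group with no aromatic ring, such as a simple methyl, a longer saturated chain or a chain ending in an amine.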